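The compounds below may be only part of what the source reports. "The series", "measured", "known", "first", "only" and "open" are said of these compounds alone.

Measured in a physicochemical assay for pharmacokinetics (a higher number here means that the compound lasts longer, a lower number that the compound disappears faster), so far:
compound 1 `O=C(NCc1ccccc1Br)N1C(=O)c2ccccc2S1(=O)=O`: 0.253 h
compound 2 `COc1ccc(CNC(=O)N2C(=O)c3ccccc3S2(=O)=O)cc1`: 0.187 h
compound 3 `O=C(NCc1ccccc1)N1C(=O)c2ccccc2S1(=O)=O`: 1.02 h

Compound 3 stands highest of the three numbers, at 1.02 h in this assay as its value. Compound 4 `O=C(NCc1ccc(Br)cc1)N1C(=O)c2ccccc2S1(=O)=O` has bromo in place of hydrogen on an aromatic carbon, para to a large group (bromo in place of hydrogen on an aromatic carbon), so 4-bromophenyl replaces phenyl. For the measured compounds named here, two measured steps bear on this, both beyond the scatter: a 4.0-fold higher number from compound 1 to compound 3 (0.61 log units; beyond the scatter) on losing bromo, and a 5.5-fold higher number from compound 2 to compound 3 (0.74 log units; beyond the scatter) on losing methoxy. Compound 1 holds 2-bromophenyl rather than 4-bromophenyl, so neither step is an exact match. A modest drop of similar size is therefore expected. The expected step is a 3.4-fold lower number from compound 3 to compound 4 (0.53 log units; beyond the scatter) by this estimate. For compound 4 the estimate is 0.3 h with an expected range from 0.12 h to 0.8 h in all.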

Compound 4, half-life: 0.187 h
The estimate for compound 4 lay 1.6-fold (0.21 log units) above the measured number; the measured number falls inside the stated range.
By their numbers in this assay, from the lowest: compounds 2, 4 and 1 (each within the scatter of the next); then compound 3.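

Bromo on the aromatic carbon para to a large group also brings the number down in this assay, with a 5.5-fold lower number from compound 3 to compound 4 (0.74 log units; beyond the scatter). The place of the bromo and the choice of bromo over methoxy show no effect beyond the scatter, with a 1.4-fold lower number from compound 1 to compound 4 (0.13 log units; within the scatter) and no change at the digits printed from compound 2 to compound 4 (within the scatter), so all three substituted compounds stand apart from compound 3 by similar steps. Nothing measured here gives a reason for this drop. Going by these compounds, whether a small group such as fluoro or methyl at this place would bring the same drop remains open. So does the effect of an amine or a carboxylic acid on the phenyl ring.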